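Swapping a hydroxy for hydrogen on a short acyl chain

The compounds below may be only part of what the source reports. "The series", "measured", "known", "first", "only" and "open" are said of these compounds alone.

Measured so far:
- compound 1, `CC(=O)NCn1cc(-c2ccc(C3=CCN(C(=O)CO)CC3)cc2)c(=O)o1`: 0.392 h
- compound 2, `CC(=O)NCn1cc(-c2ccc(-c3cncnc3)cc2)c(=O)o1`: 1.72 h

Two compounds sharing one core have been run through an ADME assay (Mus musculus) for pharmacokinetics; a higher number here means that the compound lasts longer, a lower number that the compound disappears faster. Compound 1, `CC(=O)NCn1cc(-c2ccc(C3=CCN(C(=O)CO)CC3)cc2)c(=O)o1`, gives 0.392 h in this assay. Compound 2, `CC(=O)NCn1cc(-c2ccc(-c3cncnc3)cc2)c(=O)o1`, gives 1.72 h in this assay. Compound 1 therefore stands at the lower of the two numbers, and the gap to compound 2 lies beyond the usual scatter of repeat measurements. The two compounds differ in more than one place, so nothing can be said about what any single change contributes.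

The next compound to be measured is compound 3, `CC(=O)NCn1cc(-c2ccc(C3=CCN(C(C)=O)CC3)cc2)c(=O)o1`. It differs from compound 1 in a single spot: hydrogen in place of hydroxy on a saturated chain carbon bound to a carbonyl carbon. Put another way, a hydroxymethyl becomes a methyl, so the (hydroxymethyl)carbonyl becomes an acetyl.

Within the data shown here, no pair of measured compounds differing in exactly this way is available, so the size of the step has to be guessed. Among the measured compounds shown here, with no comparable step to lean on, the expectation is a step from compound 1 to compound 3 of a 1.3-fold higher number from compound 1 to compound 3 (0.11 log units; within the scatter), which is not beyond the scatter. Compound 3 is accordingly estimated at 0.5 h, within a range from 0.2 h to 1.3 h.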

Compound 3, half-life: 0.107 h
Compound 3: middle estimate off by 4.7-fold (0.67 log units), on the high side; the whole stated range lies above it.
By their numbers in this assay, from the lowest: compound 3; then compound 1; then compound 2.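

In this assay, putting hydrogen in place of hydroxy on the saturated chain carbon bound to a carbonyl carbon gives a 3.7-fold lower number from compound 1 to compound 3 (0.56 log units; beyond the scatter). Among these compounds, this is the first comparison here in which only one place changes, and it shows that this spot is not a silent one: the (hydroxymethyl)carbonyl compound lasts longer than the acetyl compound, by a margin beyond the usual scatter, and the direction is the opposite of a change that leaves the half-life untouched. Nothing at hand explains why the half-life moves with this change, so the step stands as an observation without a cause.

On these data alone, this is a single pair on a single core, so it remains open whether the same step would appear on a different core, and the step between compound 2 and either of the others cannot be read, as they differ in more than one place. Also open, as far as these compounds go, is whether the longer half-life needs the hydroxy itself, since a methoxy, an amine or a carboxylic acid at this carbon, or a longer chain ending in hydroxy, could each read differently.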